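This account rests on a few compounds, and the source may have more. Where it says the series, first, only, none or still open, it means among the compounds named here.

Measured in an in vitro ADME assay on microsomes from liver (Macaca fascicularis) for metabolic stability; a higher number here means faster removal of the compound, a lower number slower removal:
- compound 1 `CC[C@H](C)[C@@H]1C(=O)N[C@H](C2Cc3ccccc3C2)C(=O)N1[C@@H](C(=O)N(C)C)c1ccc(C)[n+]([O-])c1`: 1 mL.min-1.g-1
- compound 2 `CCC(CC)[C@@H]1C(=O)N[C@H](C2Cc3ccccc3C2)C(=O)N1[C@@H](C(=O)NC)c1ccc(C)nc1C`: 31 mL.min-1.g-1
- compound 3 `CCC(CC)[C@@H]1C(=O)N[C@H](C2Cc3ccccc3C2)C(=O)N1[C@@H](C(=O)N(C)C)c1ccc(C)nc1`: 12 mL.min-1.g-1

Compound 1 has the lowest number of the three, and the numbers of compound 3 and compound 2 both lie above it by more than the usual scatter. So compound 1 is removed most slowly in this assay.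

The next compound to be measured is compound 4 `CC[C@H](C)[C@@H]1C(=O)N[C@H](C2Cc3ccccc3C2)C(=O)N1[C@@H](C(=O)N(C)C)c1cc(C)cnc1C`, which differs from compound 1 in one place: a group of 8 heavy atoms (7 carbon, 1 nitrogen; one six-membered aromatic ring with 1 hetero atom) in place of a group of 8 heavy atoms (6 carbon, 1 nitrogen, 1 oxygen; one six-membered aromatic ring with 1 hetero atom), on a saturated chain carbon bound to an amide-type nitrogen in a ring and a carbonyl carbon. The entering 2,5-dimethylpyridin-3-yl sits on a saturated chain carbon bound to an amide-type nitrogen in a ring and a carbonyl carbon.

Within the data shown here, no measured pair isolates this change, so the evidence is indirect. The aromatic groups of compound 3 and compound 2 hold no oxygen, and neither does the entering group. Those two compounds also differ from compound 4 elsewhere, yet compound 3 gives 12 mL.min-1.g-1 and compound 2 gives 31 mL.min-1.g-1. A clear rise beyond the scatter is therefore expected, and the estimated change is a 14-fold higher number from compound 1 to compound 4 (1.15 log units; beyond the scatter). For compound 4 the expected value is 14 mL.min-1.g-1, with an estimated range of 5 mL.min-1.g-1 to 40 mL.min-1.g-1.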

Compound 4, intrinsic clearance in microsomes: 13 mL.min-1.g-1
For compound 4 the middle estimate is 1.1-fold (0.03 log units) above the measured one; the measured number falls inside the stated range.
By their numbers in this assay, from the lowest: compound 1; then compounds 3 and 4 (each within the scatter of the next); then compound 2.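

In this assay, replacing the oxygen-bearing aromatic group of compound 1 with 2,5-dimethylpyridin-3-yl, on a saturated chain carbon bound to an amide-type nitrogen in a ring and a carbonyl carbon, gives a 13-fold higher number from compound 1 to compound 4 (1.11 log units; beyond the scatter). Among these compounds, this is the first step here between two compounds that differ in one place, and it shows that the group at this place can strongly change the number in this assay. The change is large even though the two groups match in heavy-atom count, in having one six-membered aromatic ring with 1 hetero atom, in hydrogen-bond donors and acceptors, and in carrying no net charge, so those shared counts do not predict the result; no measurement available here explains the size of this step.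

The two groups differ in more than one feature, including the oxygen and the extra carbon, so this single step cannot assign the rise to either one. The compounds shown also leave open how a methoxy group or a chlorine atom on the aromatic ring at this place would compare.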